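The source may hold more compounds than are shown below. What is called first, only, known or untested is meant among the compounds shown, and "the series" means these compounds.

In an ADME assay on HCT-116 cells (Homo sapiens) for cytotoxicity, read by MTT assay, with a stated time of 72 h (on this read-out lower numbers stand for stronger inhibition and higher numbers for weaker inhibition), compound 3 `COc1ccc(OC)c(NC(=O)c2cccc(/C=C3\CC(=O)N(c4ccccc4)C3=O)c2)c1` gives only a limit, > 100000 nM. Its two neighbours in the series fare no differently. Compound 1 `Cc1ccc(NC(=O)c2cccc(/C=C3\CC(=O)N(c4ccccc4)C3=O)c2)cc1C` likewise gives a limit of > 100000 nM. Compound 2 `COc1ccc(NC(=O)c2cccc(/C=C3\CC(=O)N(c4ccccc4)C3=O)c2)cc1` also gives a limit of > 100000 nM. The steps among these three are therefore not readable: a step that the two limits leave unreadable from compound 1 to compound 2, a step that the two limits leave unreadable from compound 1 to compound 3 and a step that the two limits leave unreadable from compound 2 to compound 3, all three hidden because every value sits at the limit of > 100000 nM in this assay, at which 3 of the 3 values shown sit. Compound 3 thus stands exactly where every measured compound stands, at the limit of this assay, with nothing to rank it against.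

The change to compound 4 `O=C(Nc1ccc(Cl)cc1)c1cccc(/C=C2\CC(=O)N(c3ccccc3)C2=O)c1` is 4-chlorophenyl in place of 2,5-dimethoxyphenyl on an amide-type nitrogen. Among the measured compounds shown here, none of the measured steps speaks to this particular exchange; together they show only that replacing one aryl group by another on that nitrogen, across the three compounds measured, left every one of them beyond the limit. On that footing compound 4 is expected to give 150000 nM, in a range from 40000 nM to 600000 nM. The step that the limit leaves unreadable from compound 3 to compound 4 is accordingly estimated as none beyond the scatter, and the most likely outcome is a further limit rather than a number.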

Compound 4, half-maximal inhibitory concentration: > 100000 nM
Compound 4: only a limit was reported (the forecaster's own chance of this, stated with the estimate: 80%); the middle value is on the limit's open side.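

Compound 4 also gives only a limit in this assay and so adds no readable step: its steps from compound 1, compound 2 and compound 3 cannot be read, and all four compounds stand at the same point: the limit of > 100000 nM in this assay, at which 4 of the 4 values shown sit.

The compounds shown leave open which change to the aryl group on the amide-type nitrogen or to the shared core, if any, would give a number in this assay rather than a limit.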